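The compounds below may be only part of what the source reports. "The series", "measured", "known", "first", "only" and "open" are said of these compounds alone.

Measured so far:
compound 1 `COc1ccc(S(=O)(=O)c2cnc3ccc(OC)cc3c2N2CCC(C)CC2)cc1` – 41%
compound 2 `Cc1ccc2ncc(S(=O)(=O)c3cc(F)cc(F)c3)c(N3CCC(C)CC3)c2c1` – 72%

In an assay on isolated protein for displacement of a labelled ligand from metabotropic glutamate receptor 5 (Homo sapiens), with a stated time of 60 min, tested at 1 uM (a higher number here means more inhibition at the concentration tested (going by the name of the read-out), a lower number less inhibition), compound 2 gives the higher of the two numbers, and compound 1 sits a long way lower, beyond the usual scatter. Compound 3 `COc1ccc2ncc(S(=O)(=O)c3cc(F)cc(F)c3)c(N3CCC(C)CC3)c2c1` has not been measured; it differs from compound 2 in one place: methoxy in place of methyl on an aromatic carbon. Going by the values given here, no measured pair shows what this single swap does on its own, since compound 1 and compound 2 differ in two places. A small drop from compound 2 to compound 3 is expected, a number 10 percentage points lower from compound 2 to compound 3 (within the scatter), within the usual scatter. For compound 3 the expected value is 62%, between 42% and 80%.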

Compound 3, a percentage reported as inhibition, at one concentration (the size of the read-out at that concentration, not a potency): 30%
Compound 3: middle estimate off by 32 percentage points, on the high side; the measured number lies below the stated range.
By their numbers in this assay, from the lowest: compound 3; then compound 1; then compound 2.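

Methoxy in place of methyl on this aromatic carbon gives a number 42 percentage points lower from compound 2 to compound 3 (beyond the scatter) in this assay, so this single swap alone costs much of the inhibition. With methoxy on the core of both compounds, 3,5-difluorophenyl in place of 4-methoxyphenyl on the sulfonyl sulfur gives a number 11 percentage points lower from compound 1 to compound 3 (beyond the scatter) and does not by itself bring the high number of compound 2. No data here explain either drop. Still open, going by these compounds, is whether a chlorine atom, an ethyl group or a hydroxyl on this aromatic carbon would keep the inhibition seen with methyl.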